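The source may report more compounds than this note shows. Statements on the series, on what has been measured and on what is new or still open speak of the compounds shown alone.

Compound 1 `CCc1cn([C@H]2CC[C@@H](CO)O2)c(=O)[nH]c1=O`: > 100 ug/mL
Compound 2 `O=c1[nH]c(=O)n([C@H]2C[C@H](F)[C@@H](CO)O2)cc1C(F)(F)F`: > 100 ug/mL

Both compounds were tested in an ADME assay on Huh-7 cells (Homo sapiens) for cytotoxicity, read by thymidine incorporation; on this read-out lower numbers stand for higher toxicity in this test and higher numbers for lower toxicity in this test. Compound 1 gives > 100 ug/mL, which is a limit of the assay and not a number. Compound 2 gives > 100 ug/mL, which is likewise a limit and not a number. Compound 2 therefore has no exact position on this scale, and the data so far amount to the limit of > 100 ug/mL in this assay, at which 2 of the 2 values shown sit.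

Compound 3 `CCc1cn([C@H]2C[C@H](F)[C@@H](CO)O2)c(=O)[nH]c1=O` has not yet been measured in this assay. It differs from compound 2 by ethyl in place of trifluoromethyl on an aromatic carbon. Among the compounds with values here, no measured pair of compounds isolates this change, so there is no direct precedent for its size. Compound 1 already carries ethyl and gives > 100 ug/mL, again a limit. On that basis, no step beyond the scatter is expected, and no direction is favoured. The expected change is a step that the limit leaves unreadable from compound 2 to compound 3, an estimate that stays within the scatter. Compound 3 is estimated at 120 ug/mL, with an expected range from 60 ug/mL to 240 ug/mL.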

Compound 3, half-maximal cytotoxic concentration: > 100 ug/mL
Compound 3: a limit, no number (the forecaster's own chance of this, stated with the estimate: 80%); the middle value does not contradict the limit.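

Compound 1, compound 2 and compound 3 all sit at the same limit of the assay, which is not a number, so no step between them can be read: the limit of > 100 ug/mL in this assay, at which 3 of the 3 values shown sit.

The compounds shown leave open where any of the three truly lies, and whether ethyl in place of trifluoromethyl or fluoro in place of hydrogen changes the read-out at all.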